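Dropping the dimethylamino from the benzyl arm of compound 3

This account rests on a few compounds, and the source may have more. Where it says the series, first, only, none or still open, it means among the compounds named here.

Compound 1 `CCN(CCCCOc1ccc(/C=C/C(=O)c2ccc(N(C)C)cc2O)cc1)Cc1ccccc1N(C)C`: 4300 nM
Compound 2 `CCN(CC)CCCOc1ccc(C(=O)/C=C/c2ccc(N(C)C)cc2)c(O)c1`: 4100 nM
Compound 3 `CCN(CCCCCCOc1ccc(C(=O)/C=C/c2ccc(N(C)C)cc2)c(O)c1)Cc1ccccc1N(C)C`: 2100 nM

In an assay on isolated protein for inhibition of Amine oxidase [flavin-containing] B (Homo sapiens) (on this read-out lower numbers stand for stronger inhibition and higher numbers for weaker inhibition), compound 3 gives 2100 nM, the lowest number of the three. Compound 2 sits within the scatter of it, while compound 1 lies beyond the scatter with its higher number. Compound 4 `CCN(CCCCCCOc1ccc(C(=O)/C=C/c2ccc(N(C)C)cc2)c(O)c1)Cc1ccccc1` differs from compound 3 by one change: hydrogen in place of dimethylamino on an aromatic carbon. Among the measured compounds shown here, no measured pair shows this change, so its size is not known from these data. On the hexyl-linked core the expectation is a step from compound 3 to compound 4 of a 1.4-fold higher number from compound 3 to compound 4 (0.15 log units; within the scatter), small, and most likely not beyond the scatter. Compound 4 is thus estimated at 3000 nM, with a range from 1000 nM to 9000 nM.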

Compound 4, half-maximal inhibitory concentration: 2100 nM
Compound 4: middle estimate off by 1.4-fold (0.15 log units), on the high side; the range from low to high includes it.
By their numbers in this assay, from the lowest: compounds 3, 4, 2 and 1 (each within the scatter of the next, the first and the last beyond it).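

Replacing dimethylamino with hydrogen on the benzyl arm gives, in this assay, no change at the digits printed from compound 3 to compound 4 (within the scatter). This first reading of the change shows that, on this core, the benzyl arm needs no dimethylamino on this aromatic carbon, ortho to a large group, for the number to stay where it is. No available evidence explains this result.

On these data alone, whether a methoxy group or a chlorine atom on this carbon would move the number remains open. So does whether the same change would behave alike on the core of compound 1.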